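This account rests on a few compounds, and the source may have more. Where it says the series, first, only, none or still open, it means among the compounds named here.

Measured compounds:
compound 1, `CC1=C(C(=O)Nc2ccc(F)cc2)C(c2ccc([N+](=O)[O-])cc2)N=C(SCc2cccc(Cl)c2)N1`: 15.9%
compound 2, `CC1=C(C(=O)Nc2ccc(F)cc2)C(c2ccc([N+](=O)[O-])cc2)N=C(SCc2ccc(Cl)cc2)N1`: 33.3%
compound 3, `CC1=C(C(=O)Nc2ccc([N+](=O)[O-])cc2)C(c2cccc([N+](=O)[O-])c2)N=C(SCc2cccc(Cl)c2)N1`: 17.9%

Of the compounds shown here, three have so far been tested in a functional assay on the whole organism (artery, strain albino) with Rattus norvegicus as the target, with a stated time of 240 min, at a dose of 10 mg/kg by the oral route; a lower number here means less inhibition, a higher number more inhibition at the dose given (going by the name of the read-out). In this assay compound 1 gives 15.9%, compound 2 gives 33.3% and compound 3 gives 17.9%.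

Compound 1 and compound 2 share one core and differ in a single place: 4-chlorophenyl in place of 3-chlorophenyl on a saturated chain carbon bound to a sulfur. This change made the step of a number 17.4 percentage points higher from compound 1 to compound 2 (beyond the scatter) in this assay.

Compound 3 carries a different core; the difference between the core of compound 3 and the core of compound 1 is not broken down here. What can be said is that in this assay compound 3 and compound 1 give values that lie within the usual scatter of each other, while compound 2 stands beyond that scatter above compound 3.

Compound 4, `CC1=C(C(=O)Nc2ccc([N+](=O)[O-])cc2)C(c2cccc([N+](=O)[O-])c2)N=C(SCc2ccc(Cl)cc2)N1`, has not yet been measured. It relates to compound 3 exactly as compound 2 relates to compound 1: 4-chlorophenyl in place of 3-chlorophenyl on a saturated chain carbon bound to a sulfur. The place of the change is the same in both pairs, so this is the same change carried over onto the second core.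

If the change behaves on the core of compound 3 as it did on the core of compound 1, a step of about the same size as a number 17.4 percentage points higher from compound 1 to compound 2 (beyond the scatter) is expected, starting from the value of compound 3 of 17.9%. The expected step from compound 3 to compound 4 is therefore a number 16.1 percentage points higher from compound 3 to compound 4 (beyond the scatter). This rests on a single measured pair, so the range is kept wide. For compound 4 the estimate in this assay is 34%, with a lower end of 18% and an upper end of 50% expected.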

Compound 4, a percentage reported as inhibition, in the whole organism at one dose (the size of the read-out at that dose, not a potency): 20%
The estimate for compound 4 lay 14 percentage points above the measured number; measured number inside the range.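

In this assay, putting 4-chlorophenyl in place of 3-chlorophenyl on the core of compound 3 gives a number 2.1 percentage points higher from compound 3 to compound 4 (within the scatter), so on this core the swap leaves no effect that can be told apart from the ordinary spread of repeated measurements. Among the compounds shown here, the same swap therefore does not carry over from one core to the other with the same size, and a step measured on one core proved a poor guide to the step on the other: the same change on two cores in this assay, a number 17.4 percentage points higher (beyond the scatter) from compound 1 to compound 2 and a number 2.1 percentage points higher (within the scatter) from compound 3 to compound 4, 15.3 percentage points apart, beyond the scatter of two such steps This shows that, for these four compounds, the result of the swap depends on the core it sits on, but it rests on only two pairs and does not show which part of the difference between the two cores is responsible, nor whether a third core would behave like either of them.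

The compounds shown leave open how the two cores would respond if the chlorophenyl on the chain carbon bound to the sulfur gave way to a plain phenyl or a methoxyphenyl. They also leave open what a longer chain between the sulfur and the ring would do, and whether the dependence on the core would persist with such groups.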